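A few compounds are considered here, and "the series" means these few. Any claim that something is new, unique, unknown or untested is made for them only; others in the source may bear on it.

In a functional assay on HepG2 cells (Homo sapiens) for cytotoxicity, read by MTT assay (on this read-out lower numbers stand for stronger inhibition and higher numbers for weaker inhibition), compound 1 `C#CCOc1cc(/C=C/C(=O)c2ccc(OC)c3c2OC(C)(C)C=C3)ccc1OC` carrying propargyl on the aromatic oxygen stands at > 10000 nM as a limit of the assay and not a number. Compound 2 `COc1ccc(/C=C/C(=O)c2ccc(OC)c3c2OC(C)(C)C=C3)cc1OCCCN(C)C` with 3-(dimethylamino)propyl on that oxygen gives 5550 nM in the same read-out. Within the data shown here, compound 3 `CCC(=O)Oc1cc(/C=C/C(=O)c2ccc(OC)c3c2OC(C)(C)C=C3)ccc1OC` with propanoyl there gives 90 nM and holds the lowest number so far.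

Among the measured compounds shown here, two measured steps bear on this end of the series: an at least 110-fold lower number from compound 1 to compound 3 (2.04 log units; beyond the scatter) and a 62-fold lower number from compound 2 to compound 3 (1.79 log units; beyond the scatter) are both large. For the measured compounds named here, each exchanges the whole group on the oxygen, and no measured step alters the propanoyl group itself.

Compound 4 `COc1ccc(/C=C/C(=O)c2ccc(OC)c3c2OC(C)(C)C=C3)cc1OC(=O)C(C)C` follows from compound 3 through methyl in place of hydrogen on a saturated chain carbon bound to a carbonyl carbon and a saturated chain carbon with propanoyl becoming isopropylcarbonyl. Compound 4 keeps the carbonyl that compound 3 carries at 90 nM so a step far smaller than those two is expected, quite possibly none beyond the scatter. The expected step is a 1.3-fold higher number from compound 3 to compound 4 (0.12 log units; within the scatter) and no firm direction is claimed for it. For compound 4 the estimated value in this assay is 120 nM with an expected range from 35 nM to 450 nM.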

Compound 4, half-maximal inhibitory concentration: 250 nM
For compound 4 the middle estimate is 2.1-fold (0.32 log units) below the measured one; the measured number falls inside the stated range.
By their numbers in this assay, from the lowest: compound 3; then compound 4; then compound 2. At a limit, above all of these: compound 1.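

In this assay the added methyl on the saturated chain carbon gives a 2.8-fold higher number from compound 3 to compound 4 (0.44 log units; beyond the scatter) and so keeping the carbonyl on this oxygen does not by itself hold the number. Isopropylcarbonyl still stands well clear of 3-(dimethylamino)propyl, with a 22-fold lower number from compound 2 to compound 4 (1.35 log units; beyond the scatter) and that gap is smaller than the one printed for propanoyl against the same group. Against propargyl the step is an at least 40-fold lower number from compound 1 to compound 4 (1.60 log units; beyond the scatter) but it rests on a limit of the assay and not a number: the limit of > 10000 nM in this assay, at which 1 of the 4 values shown sits.

As far as these compounds go, whether the number keeps rising as the acyl group grows stays open, for instance with pivaloyl or a longer chain such as hexanoyl, as does whether the smaller acetyl would change it in either direction. Also open, from the compounds shown here alone, is whether an amide linkage in place of the ester on this oxygen would keep numbers of this order.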